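The compounds below may be only part of what the source reports. "The series", "measured", "known", "first", "only" and "open" are said of these compounds alone.

The measured compounds are:

- compound 1, `COc1cc(-c2nnc3n2NC(c2cccs2)C(C(=O)c2ccccc2)S3)cc(OC)c1OC`: 86300 nM
- compound 2, `COc1cc(-c2nnc3n2NC(c2cccs2)C(C(=O)c2ccc(F)cc2)S3)cc(OC)c1OC`: 27400 nM
- compound 3, `COc1cc(-c2nnc3n2NC(c2ccco2)C(C(=O)c2ccc(C)cc2)S3)cc(OC)c1OC`: 7500 nM

All three were tested in a functional assay on PC-3 cells (Homo sapiens) for cytotoxicity, read by MTT assay, with a stated time of 48 h; a higher number here means a weaker inhibitor, a lower number a stronger inhibitor. Compound 3 gives the lowest of the three numbers: compound 2 is nearest, and compound 1 furthest. Going by the values given here, the only single-point step among the measured compounds is a 3.1-fold lower number from compound 1 to compound 2 (0.50 log units; beyond the scatter), a change on the aromatic ring attached to the carbonyl carbon.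

Compound 4, `COc1cc(-c2nnc3n2NC(c2ccco2)C(C(=O)c2ccco2)S3)cc(OC)c1OC`, differs from compound 3 in that same region: furan-2-yl in place of 4-methylphenyl on a carbonyl carbon. Among the compounds with values here, no measured pair shows this exact exchange, so the step from compound 1 to compound 2 is the only guide to how much the ring on the carbonyl carbon matters; it moved the number modestly, and in that pair only a ring substituent changed, not the ring itself. The exchange of a whole ring is larger, so compound 4 is expected to move beyond the scatter, most likely towards a higher number, as a 1.7-fold higher number from compound 3 to compound 4 (0.24 log units; within the scatter). Compound 4 is therefore estimated at 13000 nM, within 3500 nM to 45000 nM.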

Compound 4, half-maximal inhibitory concentration: 58300 nM
Estimate against measurement, compound 4: 4.5-fold (0.65 log units) below, outside the stated range (above it).
By their numbers in this assay, from the lowest: compound 3; then compound 2; then compounds 4 and 1 (each within the scatter of the next).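

In this assay, going by these compounds alone, the only earlier step at this position, a 3.1-fold lower number from compound 1 to compound 2 (0.50 log units; beyond the scatter), came from a fluoro in place of hydrogen on the ring attached to the carbonyl carbon. The new result, a 7.8-fold higher number from compound 3 to compound 4 (0.89 log units; beyond the scatter), shows that exchanging the whole ring, 4-methylphenyl for furan-2-yl, also moves the number beyond the scatter, here towards a weaker inhibitor. No measurement at hand gives a reason for this step.

Compound 2 and compound 3 differ in more than one place, so the fluoro and methyl substituents on that ring cannot be set against each other. Going by these compounds, whether the carbonyl carbon needs an aromatic ring at all remains open, as does the effect of a longer alkyl chain there or an amine or carboxylic acid on the ring.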